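Removing the urea side chain from compound 3

The compounds below may be only part of what the source reports. "The series", "measured", "known", "first", "only" and "open" are said of these compounds alone.

Compounds measured in a functional assay on A549 cells (Homo sapiens) for inhibition, read by sulforhodamine B assay, with a stated time of 72 h; a higher number here means a weaker inhibitor, a lower number a stronger inhibitor:
Compound 1 `Nc1sc(-c2ccc(Cl)cc2)c(-c2ccc(Cl)cc2)c1C(=O)Nc1ccccc1`: 25000 nM
Compound 2 `CCCCNC(=O)c1c(N)sc(-c2ccc(Cl)cc2)c1-c1ccc(Cl)cc1`: 8170 nM
Compound 3 `CCN(CC)CCNC(=O)Nc1sc(-c2ccc(Cl)cc2)c(-c2ccc(Cl)cc2)c1C(=O)NC1CC1`: "not determined" (no result reported)

Compound 3 offers no number to start from, so no size or direction of step can be stated for the change to compound 4 `Nc1sc(-c2ccc(Cl)cc2)c(-c2ccc(Cl)cc2)c1C(=O)NC1CC1`. That change is hydrogen in place of (2-(diethylamino)ethyl)carbamoyl on a nitrogen on an aromatic ring, with hydrogen in place of (2-(diethylamino)ethyl)carbamoyl on a nitrogen on an aromatic ring. Among the compounds with values here, no measured step covers it. Within the data shown here, the only step, a 3.1-fold lower number from compound 1 to compound 2 (0.49 log units; beyond the scatter), is modest and concerns the amide-type nitrogen instead. Compound 4 shares the amino group of compound 1 and compound 2, so its value is expected near theirs, given compound 2 at 8170 nM and compound 1 at 25000 nM. For compound 4, the estimate in this assay is 12000 nM, with an expected range of 4000 nM to 32000 nM.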

Compound 4, half-maximal inhibitory concentration: 1950 nM
Beside the measured number, compound 4's estimate is 6.2-fold (0.79 log units) above it, outside the stated range (below it).
By their numbers in this assay, from the lowest: compound 4; then compound 2; then compound 1.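

In this assay, within the data shown here, cyclopropyl in place of butyl on the amide-type nitrogen gives a 4.2-fold lower number from compound 2 to compound 4 (0.62 log units; beyond the scatter) and cyclopropyl in place of phenyl gives a 13-fold lower number from compound 1 to compound 4 (1.11 log units; beyond the scatter), so this position moves the number further than the single earlier step showed. The change from compound 3 to compound 4 cannot be read, as compound 3 has no number. No measurement shown accounts for this order among the amides.

On these data alone, whether (2-(diethylamino)ethyl)carbamoyl on the aromatic ring's nitrogen raises or lowers the number stays open. So does whether cyclobutyl or isopropyl on the amide-type nitrogen would stand nearer compound 4 or compound 2.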